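The compounds below may be only part of what the source reports. "The series", "measured", "known", "first", "only" and "open" are said of these compounds alone.

The study compares three measured esters built on one shared core. Compound 1 `CC(=O)Oc1ccccc1C(=O)O[C@H]1CO[C@H]2[C@@H]1OC[C@H]2OC(=O)c1ccccc1O` carries 2-hydroxyphenyl on a carbonyl carbon; in an ADME assay on a cell-free system (plasma, Homo sapiens) for metabolic stability, with Plasma (Rattus norvegicus) as the target, read by HPLC, at pH 7.4 (on this read-out higher numbers stand for a longer-lived compound and lower numbers for a shorter-lived compound), compound 1 gives 0.019 h. Compound 2 `CC(=O)Oc1ccccc1C(=O)O[C@H]1CO[C@H]2[C@@H]1OC[C@H]2OC(=O)c1ccc(O)cc1` carries 4-hydroxyphenyl instead, and in this assay compound 2 gives 0.0198 h. Compound 3 `CC(=O)Oc1ccccc1C(=O)O[C@H]1CO[C@H]2[C@@H]1OC[C@H]2OC(=O)c1ccc(C)cc1` carries 4-methylphenyl, and in this assay compound 3 gives 0.0362 h. Compound 2 thus holds the second highest of the three numbers: its nearest number is shown by a 1.0-fold higher number from compound 1 to compound 2 (0.02 log units; within the scatter) and its furthest by a 1.8-fold higher number from compound 2 to compound 3 (0.26 log units; within the scatter). The remaining step, a 1.9-fold higher number from compound 1 to compound 3 (0.28 log units; within the scatter), also lies within the scatter, so the three measured compounds cannot be ordered.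

Compound 4 `CC(=O)Oc1ccccc1C(=O)O[C@H]1CO[C@H]2[C@@H]1OC[C@H]2OC(=O)c1ccc(C#N)cc1` has not yet been measured. Its difference from compound 2 is cyano in place of hydroxy on an aromatic carbon, or, cut one bond further out, 4-hydroxyphenyl to 4-cyanophenyl. For the measured compounds named here, the one measured step that touches this same aromatic carbon, a 1.8-fold higher number from compound 2 to compound 3 (0.26 log units; within the scatter), put methyl in place of hydroxy and stayed within the scatter, as did every other step here. Going by the values given here, nothing among the measured compounds points to a step beyond the scatter in this assay, so compound 4 is expected to sit close to compound 2, with a 1.3-fold higher number from compound 2 to compound 4 (0.10 log units; within the scatter) as the estimated step. The value of compound 4 in this assay is estimated at 0.025 h, within a range from 0.012 h to 0.05 h.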

Compound 4, half-life: 0.068 h
Compound 4: middle estimate off by 2.7-fold (0.43 log units), on the low side, outside the stated range (above it).
By their numbers in this assay, from the lowest: compounds 1, 2, 3 and 4 (each within the scatter of the next, the first and the last beyond it).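

In this assay, for the compounds shown here, this change gives the first step beyond the scatter at this aromatic carbon (a 3.4-fold higher number from compound 2 to compound 4 (0.54 log units; beyond the scatter)), and the wider exchange of 2-hydroxyphenyl for 4-cyanophenyl also goes beyond it (a 3.6-fold higher number from compound 1 to compound 4 (0.55 log units; beyond the scatter)). The group on this carbon, para to a large group, can therefore shift the half-life by more than the scatter, although the effect is modest and the exchange of methyl for cyano at the same place stays within the scatter (a 1.9-fold higher number from compound 3 to compound 4 (0.27 log units; within the scatter)), so the data separate cyano from hydroxy but not from methyl. No measurement offered here accounts for the step from hydroxy to cyano.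

From the compounds shown here alone, what an amine, a carboxylic acid or a trifluoromethyl group on this same carbon would give remains open, and so does whether any of them would stand clearly apart from both cyano and methyl. Going by these compounds, it is also open whether the step from hydroxy to cyano would hold with a different ester on the other side of the shared core, which is the same in all four compounds.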